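This account rests on a few compounds, and the source may have more. Where it says the series, first, only, none or still open, it means among the compounds named here.

Series notes, acylurea core with a benzyloxy arm.

Compound 2 `Cc1ccc(NC(=O)NC(=O)c2ccc(OCc3ccccc3Cl)cc2)cc1-c1nc2ccccc2[nH]1` is the parent with one chloro on the benzyl ring. For the measured compounds named here, in a functional assay on SW-620 cells (Homo sapiens) for inhibition, read by MTT assay, with a stated time of 48 h (on this read-out higher numbers stand for weaker inhibition and lower numbers for stronger inhibition), compound 2 gives 35700 nM, the highest of the two numbers so far. Going by the values given here, its nearest neighbour is compound 1 `Cc1ccc(NC(=O)NC(=O)c2ccc(OCc3ccccc3)cc2)cc1-c1nc2ccccc2[nH]1`, which in this assay gives 30100 nM; the only step measured, a 1.2-fold higher number from compound 1 to compound 2 (0.07 log units; within the scatter), stays within the scatter, so the two compounds cannot be set in any order on these data.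

Compound 3 `Cc1ccc(NC(=O)NC(=O)c2ccc(OCc3ccc(Cl)c(Cl)c3)cc2)cc1-c1nc2ccccc2[nH]1` is unmeasured. Relative to compound 2 the change is 3,4-dichlorophenyl in place of 2-chlorophenyl on a saturated chain carbon bound to an oxygen on an aromatic ring. Among the compounds with values here, the one step available, a 1.2-fold higher number from compound 1 to compound 2 (0.07 log units; within the scatter), bears on it in that it also places a chloro on that same aromatic ring, and it produced no movement beyond the scatter. Within the data shown here, no step with a second chloro on this ring has been measured, so there is no basis for predicting a shift in either direction.

For compound 3 in this assay the expected step is a 1.1-fold lower number from compound 2 to compound 3 (0.02 log units; within the scatter), that is, no change beyond the scatter. The estimate for compound 3 is therefore 34000 nM, with a range from 14000 nM to 85000 nM.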

Compound 3, half-maximal inhibitory concentration: 6100 nM
Beside the measured number, compound 3's estimate is 5.6-fold (0.75 log units) above it, and the stated range ends above it.
By their numbers in this assay, from the lowest: compound 3; then compounds 1 and 2 (each within the scatter of the next).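

In this assay the aromatic ring on the saturated chain carbon bound to an oxygen on an aromatic ring now proves able to shift the read-out: 3,4-dichlorophenyl in place of 2-chlorophenyl gives a 5.9-fold lower number from compound 2 to compound 3 (0.77 log units; beyond the scatter) and 3,4-dichlorophenyl in place of phenyl gives a 4.9-fold lower number from compound 1 to compound 3 (0.69 log units; beyond the scatter). For the compounds shown here, these modest steps are the first beyond the scatter, whereas the only earlier step, a 1.2-fold higher number from compound 1 to compound 2 (0.07 log units; within the scatter), showed no readable effect of the single chloro in 2-chlorophenyl, so the presence of a chloro on this ring does not by itself set compound 3 apart from compounds 1 and 2. No measured data on these compounds account for the shift.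

Still open, as far as these compounds go, is whether the step depends on both chloro atoms of the 3,4-dichlorophenyl group or on one of them alone, since the change from compound 2 alters their number and their placement together. Also open, from the compounds shown here alone, is whether other groups on this ring, such as methoxy, trifluoromethyl or an amine, or a longer chain in place of the benzyl carbon, would move the number further in either direction.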